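Replacing a sulfonamide by a methylamide on a shared core

The compounds below may be only part of what the source reports. "The series", "measured", "known", "first", "only" and "open" are said of these compounds alone.

Compound 1, `Cn1ccc(-c2cccc3c2CCC3c2ncc[nH]2)n1`, gives in a functional assay on CHO cells for agonist activity at Alpha-1B adrenergic receptor (Homo sapiens), read by FLIPR and calcium flux (a higher number here means that more compound is needed for the effect, a lower number that less compound is needed), a value of > 10000 nM, which is a limit of the assay rather than a number.
Compound 2, `CS(=O)(=O)Nc1cccc2c1CCC2c1ncc[nH]1`, gives in this assay a value of > 10000 nM, again only a limit of the assay.

Compound 2 therefore stands at the assay limit, and both values shown so far sit there, as stated by the limit of > 10000 nM in this assay, at which 2 of the 2 values shown sit. Going by the values given here, the only measured step, a step that the two limits leave unreadable from compound 1 to compound 2, cannot be sized for that reason.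

Compound 3, `CNC(=O)c1cccc2c1CCC2c1ncc[nH]1`, differs from compound 2 by methylcarbamoyl in place of methanesulfonamido on an aromatic carbon. Among the compounds with values here, no measured step reports a readable size for a change of this kind, so the expectation rests on the limit alone. The step that the limit leaves unreadable from compound 2 to compound 3 from compound 2 to compound 3 is expected to be none beyond the scatter, with compound 3 most likely also reported as a limit. Compound 3 is estimated at 15000 nM, with a range from 4000 nM to 60000 nM.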

Compound 3, half-maximal effective concentration: > 10000 nM
Compound 3: only a limit was reported; the forecaster's own chance of this, stated with the estimate: 80%; the middle value is on the limit's open side.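

The result for compound 3 is > 10000 nM in this assay, again only a limit of the assay, so its steps from compound 1 and from compound 2 cannot be read: the limit of > 10000 nM in this assay, at which 3 of the 3 values shown sit.

The compounds shown leave open how the 1-methyl-1H-pyrazol-3-yl, methanesulfonamido and methylcarbamoyl groups rank against one another in this assay.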